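Benzotriazole series: aryl substituent swap, clearance expectations

The compounds below may be only part of what the source reports. "The series", "measured", "known", "first", "only" and "open" are said of these compounds alone.

The shared core carries a cyclopropylmethyl group on the triazole nitrogen and a single substituent on the carbocyclic ring. Within the data shown here, compound 1 `Clc1cccc2c1nnn2CC1CC1` is the only member with a recorded number: in an ADME assay on microsomes from liver (Mus musculus, strain NMRI) for metabolic stability, tested at 2.5 uM (a higher number here means faster removal of the compound, a lower number slower removal), compound 1 gives 5.7 mL/min/g. Compound 2 `Fc1cccc2c1nnn2CC1CC1` has no result in this assay, recorded as "not determined" (no result reported). Compound 3 `N#Cc1cccc2c1nnn2CC1CC1` likewise stands without a number in this assay, recorded as "not determined" (no result reported), so its position relative to compound 1 cannot be read from the data at hand; one further entry in the set is in the same situation.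

Compound 4 `COc1cccc2c1nnn2CC1CC1` has not yet been measured. The change from compound 3 to compound 4 is methoxy in place of cyano on an aromatic carbon.

Among the measured compounds shown here, no step between two measured compounds is available, so the size of the change cannot be anchored on a precedent. Because compound 1 gives 5.7 mL/min/g, the series appears capable of fairly brisk turnover, and a value of similar magnitude is expected for compound 4 rather than a slow-clearance outlier; the direction relative to compound 3 cannot be stated since compound 3 has no number. Compound 4 is therefore estimated at 8 mL/min/g in this assay, with an expected range from 3 mL/min/g to 22 mL/min/g.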

Compound 4, intrinsic clearance in a liver preparation (reported as CLH), per the amount of preparation that the assay uses: 8.3 mL/min/g
Estimate against measurement, compound 4: 1.0-fold (0.02 log units) below, within the range that was stated.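

Methoxy in place of chloro on this aromatic carbon is the only change in the series that can be read in this assay, and it gives a 1.5-fold higher number from compound 1 to compound 4 (0.16 log units; within the scatter), so the two groups cannot be told apart at this position in this assay and the turnover seen for compound 1 is no longer a single isolated reading. The steps that involve compound 2 or compound 3 cannot be read, neither compound having a number, and the comparison therefore rests on one pair and says nothing yet about fluoro or cyano at this carbon. No supporting measurement bears on why chloro and methoxy sit within the scatter of each other here.

Going by these compounds, whether an amine or a carboxylic acid on the same aromatic carbon would stay within the scatter of compound 1 and compound 4 in this assay remains open. Also open, on these data alone, is how much of the clearance follows the substituent at all rather than the cyclopropylmethyl group, which a longer chain such as n-butyl on the triazole nitrogen would test.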